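The source may hold more compounds than are shown below. What is called first, only, known or untested is meant among the compounds shown, and "the series" means these compounds.

Measured compounds:
Compound 1, `CC1(C)C=C(n2ccccc2=O)c2ccccc2O1`: 5.43
Compound 2, `CC1(C)C=C(n2ccccc2=O)c2cc(C(=O)c3ccccc3F)ccc2O1`: 7.08
Compound 3, `CC1(C)C=C(n2ccccc2=O)c2cc(C#N)ccc2O1`: 7.67

All three were tested in a functional assay (aorta) with Rattus norvegicus as the target; on this read-out higher numbers stand for higher potency (the scale is a negative logarithm) and lower numbers for lower potency. Compound 3 stands highest of the three numbers; its nearest neighbour is compound 2, and compound 1 lies furthest below it. The two steps that lead into compound 3 both rise: a number 2.24 log units higher from compound 1 to compound 3 (beyond the scatter) and a number 0.59 log units higher from compound 2 to compound 3 (beyond the scatter). The step of a number 1.65 log units higher from compound 1 to compound 2 (beyond the scatter) shows that the (2-fluorophenyl)carbonyl also lifts potency well over hydrogen at the same place.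

Compound 4, `CC1(C)C=C(n2ccccc2=O)c2cc(C(=N)S)ccc2O1`, has not yet been measured in this assay. It differs from compound 3 in one change: a group of 3 heavy atoms (1 carbon, 1 nitrogen, 1 sulfur; no ring) in place of a group of 2 heavy atoms (1 carbon, 1 nitrogen; no ring), on an aromatic carbon. Within the data shown here, no measured step replaces the cyano with a group of this kind, so the bearing steps are indirect. Both steps into compound 3 show that a substituent on that aromatic carbon is worth a good deal over hydrogen, while the step from the carbonyl-bearing compound 2 shows that the cyano is the better of two such substituents. The incoming group is neither of those. Compound 4 is therefore expected to show a step of a number 0.57 log units lower from compound 3 to compound 4 (beyond the scatter) rather than to match or exceed the cyano compound. The estimate for compound 4 is 7.1, with a range from 6.3 to 7.9.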

Compound 4, logarithm of the reciprocal of the active concentration, log(1/C): 6.21
Estimate against measurement, compound 4: 0.89 log units above, and the stated range ends above it.
By their numbers in this assay, from the lowest: compound 1; then compound 4; then compound 2; then compound 3.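

Hydrogen on this aromatic carbon is not the ceiling, yet the gain depends on the group: the new group still gives a number 0.78 log units higher from compound 1 to compound 4 (beyond the scatter) in this assay but also gives a number 1.46 log units lower from compound 3 to compound 4 (beyond the scatter) when it takes the place of the cyano. It also trails the (2-fluorophenyl)carbonyl, with a number 0.87 log units lower from compound 2 to compound 4 (beyond the scatter) as the step between those two substituted compounds, so it stands lowest of the three groups tried at this place. Heavy-atom count does not set this order, since the cyano with 2 heavy atoms stands highest, the (2-fluorophenyl)carbonyl with 9 comes next, and the entering group with 3 comes last.

Nothing available here bears on what lies behind the fall from the cyano compound. Going by these compounds, whether an amine, a carboxylic acid or a methyl group on the same aromatic carbon would stand nearer to the cyano or nearer to hydrogen stays open, and so does whether the order of these three groups would hold on a core other than the shared one.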